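Notes on the chain terminus in the series

The source may report more compounds than this note shows. Statements on the series, on what has been measured and on what is new or still open speak of the compounds shown alone.

Of the compounds shown here, two have been measured in an assay on HEK293 cells for agonist activity at Toll-like receptor 8 (Homo sapiens), read by spectrophotometry; a higher number here means that more compound is needed for the effect, a lower number that less compound is needed. Compound 1 `CCCCNc1nc(N)nc(C)c1CCCCc1ccccc1` gives 857 nM in this assay. Compound 2 `CCCCNc1nc(N)nc(C)c1CCCc1ccccc1` gives 749 nM in this assay. The step of a 1.1-fold lower number from compound 1 to compound 2 (0.06 log units; within the scatter) shows that shortening the chain by one carbon left the number essentially unchanged. Compound 2 thus holds the lowest of the two numbers, but its nearest neighbour, compound 1, sits within the scatter of it, so no order between them can be read.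

Compound 3 `CCCCNc1nc(N)nc(C)c1CCCN(CC)CC` is not yet measured in this assay. It differs from compound 2 by diethylamino in place of phenyl on a saturated chain carbon, three bonds along the chain from an aromatic carbon. Among the measured compounds shown here, no measured step bears directly on this exchange: the one step known, from compound 1 to compound 2, concerns only the length of the chain and stays within the scatter. For the measured compounds named here, the change in compound 3 swaps a carbon ring for an open acceptor-bearing group, for which the series gives no precedent.

Going by the values given here, the expectation for compound 3 is therefore the step of a 1.0-fold higher number from compound 2 to compound 3 (0.00 log units; within the scatter), that is, an estimate of 750 nM in this assay, with a range from 150 nM to 3800 nM, kept wide since no step informs it.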

Compound 3, half-maximal effective concentration: 254 nM
For compound 3 the middle estimate is 3.0-fold (0.47 log units) above the measured one; the range from low to high includes it.
By their numbers in this assay, from the lowest: compound 3; then compounds 2 and 1 (each within the scatter of the next).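

Working notes on the terminus after compound 3

The chain terminus now shows a change that can be read: in this assay diethylamino in place of phenyl gives a 2.9-fold lower number from compound 2 to compound 3 (0.47 log units; beyond the scatter) and diethylamino in place of benzyl gives a 3.4-fold lower number from compound 1 to compound 3 (0.53 log units; beyond the scatter) and so, unlike the shortening of the chain, both modest steps lie beyond the scatter. Among these three compounds, a six-membered aromatic ring of carbon only is thus not needed at this position for a number in this range, and compound 3, with an open group holding one nitrogen, gives the lowest number of the three. No supporting measurement accompanies this result, so the reason for the lower number stays unknown.

From the compounds shown here alone, whether the lower number goes with the entering nitrogen or with the loss of the ring remains open: cyclohexyl at the same place would keep a ring without nitrogen, while piperidine would hold the nitrogen inside a ring. Also open, going by these compounds, is whether chain length, which made no readable difference with phenyl at the terminus, matters with diethylamino there, as a longer chain ending in diethylamino would show.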